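Sulfur pentafluoride series: fluoro replacement on the thioether/sulfone arm

The source may report more compounds than this note shows. Statements on the series, on what has been measured and on what is new or still open speak of the compounds shown alone.

Measured compounds, all in a functional assay on DU-145 cells (Homo sapiens) for antiproliferative activity, read by propidium iodide staining, with a stated time of 96 h; on this read-out lower numbers stand for stronger inhibition and higher numbers for weaker inhibition:

Compound 1 `CC(O)(CSc1ccc(S(F)(F)(F)(F)F)cc1)C(=O)Nc1ccc(S(F)(F)(F)(F)F)cc1`: compound 1 gives 22300 nM.
Compound 2 `CC(O)(CSc1ccc(F)cc1)C(=O)Nc1ccc(S(F)(F)(F)(F)F)cc1`: compound 2 gives 25400 nM.
Compound 3 `CC(O)(CS(=O)(=O)c1ccc(S(F)(F)(F)(F)F)cc1)C(=O)Nc1ccc(S(F)(F)(F)(F)F)cc1`: compound 3 gives 28900 nM.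

Compounds 1 and 2 share one core; compounds 3 and 4 share another. The difference between the two cores is not broken down here. Compound 3 stands highest of the three numbers, but its gap to compound 2 and to compound 1 is within the scatter, so no order among them is claimed.

From compound 1 to compound 2 the change is one fluorine atom in place of a group of 6 heavy atoms (5 fluorine, 1 sulfur; no ring), on an aromatic carbon, and the step is a 1.1-fold higher number from compound 1 to compound 2 (0.06 log units; within the scatter). The same change is now made on the other core: compound 4 `CC(O)(CS(=O)(=O)c1ccc(F)cc1)C(=O)Nc1ccc(S(F)(F)(F)(F)F)cc1` differs from compound 3 by one fluorine atom in place of a group of 6 heavy atoms (5 fluorine, 1 sulfur; no ring), on an aromatic carbon, the place being the same word for word in both pairs. It is the only repeat of this change among the compounds shown.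

For the measured compounds named here, for compound 4 the step is expected to be a 1.1-fold higher number from compound 3 to compound 4 (0.03 log units; within the scatter) in this assay, since the one earlier instance of the change, a 1.1-fold higher number from compound 1 to compound 2 (0.06 log units; within the scatter), moved the number by less than the scatter, and there is nothing in the other compounds to suggest the sulfone core would respond differently. Compound 4 is accordingly estimated at 31000 nM, with a range of 15000 nM to 65000 nM.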

Compound 4, half-maximal inhibitory concentration: 27700 nM
Compound 4: middle estimate off by 1.1-fold (0.05 log units), on the high side; measured number inside the range.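

In this assay, exchanging the group of 6 heavy atoms for fluoro on the sulfone core gives a 1.0-fold lower number from compound 3 to compound 4 (0.02 log units; within the scatter), so on this core as well the exchange leaves the number unmoved beyond the scatter. Set beside the earlier instance on the thioether core, the two steps do not differ beyond what two such steps allow: the same change on two cores in this assay, a 1.1-fold higher number (0.06 log units; within the scatter) from compound 1 to compound 2 and a 1.0-fold lower number (0.02 log units; within the scatter) from compound 3 to compound 4, 1.2-fold (0.07 log units) apart, within the scatter of two such steps Within this series the flat result therefore carries from one core to the other, but this rests on only two matched pairs in a single cell assay, all with numbers of similar size, and it shows neither that the two groups are interchangeable on other cores or in other assays nor why the number stays put.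

The compounds shown leave open whether any group at this aromatic carbon moves the number beyond the scatter, for example a nitrile, an amine or a carboxylic acid, since both groups seen here give results that cannot be told apart. On these data alone, all four compounds also keep the second copy of the group of 6 heavy atoms on the other aromatic ring, so what happens when that copy is exchanged for fluoro, or for a longer chain, remains open.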